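Trifluoromethoxy in place of the six-atom group, one step

This account rests on a few compounds, and the source may have more. Where it says the series, first, only, none or still open, it means among the compounds named here.

Measured so far in a functional assay on CWR22R cells (Homo sapiens) for antiproliferative activity, read by propidium iodide staining, with a stated time of 96 h; a higher number here means a weaker inhibitor, a lower number a stronger inhibitor:
compound 1, `CC(O)(CSc1ccc(S(F)(F)(F)(F)F)cc1)C(=O)Nc1cccc(S(F)(F)(F)(F)F)c1`, 13100 nM
compound 2, `CC(O)(CSc1ccc(OC(F)(F)F)cc1)C(=O)Nc1cccc(S(F)(F)(F)(F)F)c1`, 17000 nM
compound 3, `CC(O)(COc1ccc(S(F)(F)(F)(F)F)cc1)C(=O)Nc1ccc(S(F)(F)(F)(F)F)cc1`, 13000 nM

Compound 1 and compound 2 share one core and differ in a single place: a group of 5 heavy atoms (1 carbon, 1 oxygen, 3 fluorine; no ring) in place of a group of 6 heavy atoms (5 fluorine, 1 sulfur; no ring), on an aromatic carbon. This change gave a 1.3-fold higher number from compound 1 to compound 2 (0.11 log units; within the scatter), so in this assay the two compounds sit within the scatter of each other and nothing can be said about the order between them.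

Compound 3 is built on a different core. How its core differs from that of compound 1 is not broken down here; in this assay compound 3 gives 13000 nM, which stands within the scatter of compound 1 and of compound 2.

Compound 4, `CC(O)(COc1ccc(OC(F)(F)F)cc1)C(=O)Nc1ccc(S(F)(F)(F)(F)F)cc1`, has not yet been measured. It stands to compound 3 as compound 2 stands to compound 1: a group of 5 heavy atoms (1 carbon, 1 oxygen, 3 fluorine; no ring) in place of a group of 6 heavy atoms (5 fluorine, 1 sulfur; no ring), on an aromatic carbon. The place line reads the same word for word in both pairs, so this is the same change, made once more on the other core.

The expectation for this assay rests on one earlier step only. Because a 1.3-fold higher number from compound 1 to compound 2 (0.11 log units; within the scatter) stayed within the scatter, the step from compound 3 to compound 4 is expected to be small as well, estimated at a 1.3-fold higher number from compound 3 to compound 4 (0.12 log units; within the scatter). Compound 4 is therefore estimated at 17000 nM, with the likely range 8000 nM to 36000 nM; a single prior instance of the change is a thin basis, and the range is set wide for that reason.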

Compound 4, half-maximal inhibitory concentration: 27900 nM
For compound 4 the middle estimate is 1.6-fold (0.22 log units) below the measured one; low and high end bracket the measured number.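

In this assay, trifluoromethoxy in place of the six-atom group on the core of compound 3 gave a 2.1-fold higher number from compound 3 to compound 4 (0.33 log units; beyond the scatter), a modest step that lies just beyond the scatter, whereas the same change on the core of compound 1 gave a 1.3-fold higher number from compound 1 to compound 2 (0.11 log units; within the scatter), which stays within it. Set side by side, the two steps cannot be told apart: the same change on two cores in this assay, a 1.3-fold higher number (0.11 log units; within the scatter) from compound 1 to compound 2 and a 2.1-fold higher number (0.33 log units; beyond the scatter) from compound 3 to compound 4, 1.7-fold (0.22 log units) apart, within the scatter of two such steps On this evidence the change can be carried from one core to the other without a detectable difference in its effect, but two pairs cannot show that its size is fixed, that the larger step on the core of compound 3 is real rather than scatter, or that the change would behave the same way on a third core.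

The two cores are not separated here into single changes, so the part played by each difference between them stays unread, and compound 2 and compound 4 cannot be compared directly. Also open, going by these compounds, is how other groups on the same aromatic carbon, such as trifluoromethyl, a nitrile, an amine or a carboxylic acid, would stand against the two groups exchanged here.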